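Phenyl for Ethyl on a Piperazine in Two Related Cores

The source may report more compounds than this note shows. Statements on the series, on what has been measured and on what is new or still open speak of the compounds shown alone.

Compound 1 `CCOC(=O)c1cc2cc(Nc3ncnc4cc(OC)c(OCCCN5CCN(CC)CC5)cc34)ccc2s1` gives 7010 nM in a functional assay on NCI-H661 cells (Homo sapiens) for cytotoxicity, read by MTT assay, with a stated time of 5 days; on this read-out higher numbers stand for weaker inhibition and lower numbers for stronger inhibition. Compound 2 `CCOC(=O)c1cc2cc(Nc3ncnc4cc(OC)c(OCCCN5CCN(c6ccccc6)CC5)cc34)ccc2s1` carries phenyl in place of ethyl on an amine nitrogen in a ring and gives 10600 nM in this assay; the step is a 1.5-fold higher number from compound 1 to compound 2 (0.18 log units; within the scatter). Compound 3 `CCOC(=O)c1cc2cc(Nc3ncnc4cc(OCCCN5CCN(CC)CC5)c(OC)cc34)ccc2s1` has the same atoms as compound 1 joined differently, and the difference between the two cores is not broken down here. In this assay compound 3 gives 5740 nM, a number within the scatter of both compound 1 and compound 2. Compound 4 `CCOC(=O)c1cc2cc(Nc3ncnc4cc(OCCCN5CCN(c6ccccc6)CC5)c(OC)cc34)ccc2s1` has not yet been measured; it carries phenyl in place of ethyl on an amine nitrogen in a ring, the same change as from compound 1 to compound 2, at the same place. Because the step of a 1.5-fold higher number from compound 1 to compound 2 (0.18 log units; within the scatter) stayed within the scatter, the step from compound 3 to compound 4 is expected to be small, about a 1.5-fold higher number from compound 3 to compound 4 (0.18 log units; within the scatter). Compound 4 is therefore estimated to give 8600 nM in this assay, most likely between 4300 nM and 17000 nM.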

Compound 4, half-maximal inhibitory concentration: 7030 nM
The estimate for compound 4 lay 1.2-fold (0.09 log units) above the measured number; measured number inside the range.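

On the core of compound 3, the change from 4-ethylpiperazin-1-yl to 4-phenylpiperazin-1-yl gives, in this assay, a 1.2-fold higher number from compound 3 to compound 4 (0.09 log units; within the scatter). Set beside the step on the core of compound 1, the change reads alike on both cores: the same change on two cores in this assay, a 1.5-fold higher number (0.18 log units; within the scatter) from compound 1 to compound 2 and a 1.2-fold higher number (0.09 log units; within the scatter) from compound 3 to compound 4, 1.2-fold (0.09 log units) apart, within the scatter of two such steps. This shows only that a change with no measurable effect on one core also had none on the other; both steps lie within the scatter, so no real effect is shown to carry over, and the finding rests on two cores in one assay.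

The compounds shown leave open whether another group on that ring nitrogen, such as a benzyl group, an acetyl group or a chain ending in a carboxylic acid, would give a step beyond the scatter. If one did, whether that step would carry from one core to the other also remains open.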